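Lactone series: hydroxy-to-methoxy step and a dichloro analogue

The compounds below may be only part of what the source reports. "The series", "measured", "known", "first", "only" and "open" are said of these compounds alone.

Measured in a functional assay on HL-60 cells (Homo sapiens) for cytotoxicity, read by WST assay, with a stated time of 48 h; a higher number here means that more compound is needed for the effect, a lower number that less compound is needed:
- compound 1, `O=C1OC[C@H](Cc2ccccc2)[C@H]1Cc1ccc(O)cc1`, gives 88000 nM
- compound 2, `COc1ccc(C[C@H]2C(=O)OC[C@@H]2Cc2ccccc2)cc1`, gives 67000 nM
- compound 3, `O=C1OC[C@H](Cc2ccc(O)cc2)[C@H]1Cc1ccc(Cl)c(Cl)c1`, gives 37000 nM

Compounds 1 and 2 differ by a single change, (methyl in place of hydrogen on an oxygen on an aromatic ring), and this gave a 1.3-fold lower number from compound 1 to compound 2 (0.12 log units; within the scatter). Compound 3 carries a different benzyl group on the shared core; the difference between its core and that of compound 1 is not broken down here. Compound 3 has the lowest of the three numbers, but its value stands within the scatter of that of compound 2 and only beyond it relative to compound 1.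

Compound 4, `COc1ccc(C[C@H]2COC(=O)[C@@H]2Cc2ccc(Cl)c(Cl)c2)cc1`, is not yet measured. It differs from compound 3 by methyl in place of hydrogen on an oxygen on an aromatic ring, the same change as between compound 1 and compound 2, at the same kind of place on the aromatic ring. The expected step is a 1.2-fold lower number from compound 3 to compound 4 (0.09 log units; within the scatter), resting on the measured 1.3-fold lower number from compound 1 to compound 2 (0.12 log units; within the scatter), which stayed within the scatter. Compound 4 is therefore estimated at 30000 nM in this assay. The estimate for compound 4 spans 12000 nM to 75000 nM.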

Compound 4, half-maximal effective concentration: 37000 nM
For compound 4 the middle estimate is 1.2-fold (0.09 log units) below the measured one; the range from low to high includes it.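

In this assay, methyl in place of hydrogen on an oxygen on an aromatic ring gave no change at the digits printed from compound 3 to compound 4 (within the scatter), and the step agrees with the one on the other core: the same change on two cores in this assay, a 1.3-fold lower number (0.12 log units; within the scatter) from compound 1 to compound 2 and no change at the digits printed (within the scatter) from compound 3 to compound 4, 1.3-fold (0.12 log units) apart, within the scatter of two such steps On the two cores shown, hydroxy to methoxy therefore behaves alike, with both steps staying within the scatter. This does not show that the change is without any effect, since steps this small cannot separate a slight real shift from none, and two pairs say nothing about how the change behaves on any other core in the series.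

At this place on the aromatic ring the compounds shown carry only hydroxy and methoxy, so it remains open whether a longer chain on the oxygen, such as ethoxy, would give a step beyond the scatter. From the compounds shown here alone, the same question remains open for an amine or a carboxylic acid in place of the hydroxy.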